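The source may hold more compounds than are shown below. What is called first, only, known or untested is meant among the compounds shown, and "the series" means these compounds.

Measured compounds in an ADME assay on BJ cells (Homo sapiens) for cytotoxicity, read by CellTiter-Glo and resazurin assay, with a stated time of 72 h; a lower number here means that less compound is needed, a higher number that more compound is needed for the effect:
- compound 1 `CCOC(=O)CCCCCOc1cccc(CN(C(=O)c2ccc(-c3ccc4cc[nH]c4c3)cc2)C(C)C)c1`: > 26000 nM, a limit of the assay, not a number.
- compound 2 `CCOC(=O)CCCCCOc1cccc(CN(C(=O)c2ccc(-c3cccc(O)c3)cc2)C(C)C)c1`: > 26000 nM, again a limit of the assay, not a number.

Compound 2 thus stands at the limit in this assay, the same limit at which compound 1 sits, so the limit of > 26000 nM in this assay, at which 2 of the 2 values shown sit, is all the two values show. Among the measured compounds shown here, the only step in the set, a step that the two limits leave unreadable from compound 1 to compound 2, is left unreadable by the two limits and gives no size to lean on.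

Compound 3 `CCOC(=O)CCCCCOc1cccc(CN(C(=O)c2ccc(-c3cccc([N+](=O)[O-])c3)cc2)C(C)C)c1` differs from compound 2 by nitro in place of hydroxy on an aromatic carbon. For the measured compounds named here, no measured step bears on this change, and the readable record is empty. Since compound 2 and compound 1 both give only a limit in this assay, the expectation for compound 3 is a value at or beyond that limit, with a step that the limit leaves unreadable from compound 2 to compound 3 expected to stay within the scatter. Compound 3 is therefore estimated at 35000 nM, with a range from 15000 nM to 90000 nM.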

Compound 3, half-maximal effective concentration: < 1.3 nM
Compound 3 was reported as a limit (the forecaster's own chance of this, stated with the estimate: 80%); middle value at least 26000-fold (4.43 log units) from the limit.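

The position meta to a large group on the six-membered aromatic ring is not silent in this assay: nitro in place of hydroxy gives an at least 20000-fold lower number from compound 2 to compound 3 (4.30 log units; beyond the scatter). The wider change from 1H-indol-6-yl to 3-nitrophenyl gives an at least 20000-fold lower number from compound 1 to compound 3 (4.30 log units; beyond the scatter), so the shared core does not by itself fix the read-out, and the substituent on this ring can move it across the whole span shown. Both sizes are bounds and the step between compound 1 and compound 2 cannot be read: the limit of > 26000 nM in this assay, at which 2 of the 3 values shown sit.

An amine or a nitrile at this same place would show whether the shift belongs to nitro alone or extends to other groups. From the compounds shown here alone, how far the true value of compound 3 lies beyond its limit also remains open.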